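The compounds below may be only part of what the source reports. "The series", "measured", "known", "first", "only" and "open" are said of these compounds alone.

Compound 1 `COc1ccc(/C=C\c2cc(OC)c(OC)c(OC)c2)cc1OCc1ccc(CN2CC[C@@H](O)C2)cc1` gives 53000 nM in an ADME assay on NCM460 cells (Homo sapiens) for cytotoxicity, read by CCK-8 assay, with a stated time of 48 h; a higher number here means a weaker inhibitor, a lower number a stronger inhibitor. Compound 2 `COc1ccc(/C=C\c2cc(OC)c(OC)c(OC)c2)cc1OCc1ccc(CN[C@H](C(=O)O)[C@@H](C)O)cc1` reaches only a limit of the assay, > 50000 nM, in this assay; it sits at the limit of > 50000 nM in this assay, at which 1 of the 2 values shown sits. The step that the limit leaves unreadable from compound 1 to compound 2 is therefore not readable in size. Compound 3 `COc1ccc(/C=C\c2cc(OC)c(OC)c(OC)c2)cc1OCc1ccc(CNC(C)(C)C(=O)O)cc1` is not yet measured and differs from compound 2 by 1-carboxy-1-methylethyl in place of 1-carboxy-2-hydroxypropyl on an amine nitrogen. Only the unreadable step from compound 1 to compound 2 bears on this change, so no direction beyond the scatter is expected; compound 3 is estimated at 60000 nM, range 30000 nM to 150000 nM. The expected step is a step that the limit leaves unreadable from compound 2 to compound 3.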

Compound 3, half-maximal inhibitory concentration: > 50000 nM
Compound 3: a limit, no number (the forecaster's own chance of this, stated with the estimate: 70%); the middle value is on the limit's open side.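

Compound 3 gives > 50000 nM, a limit of this assay and not a number, so its steps from compound 1 and compound 2 cannot be read. Left open is whether 1-carboxy-1-methylethyl in place of 1-carboxy-2-hydroxypropyl changes the read-out at all.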